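A few compounds are considered here, and "the series" means these few. Any claim that something is new, unique, unknown or untested is made for them only; others in the source may bear on it.

Working notes on the sulfonyl series. Compound 3 `COc1ccc(-c2cc(=O)c3c(OC)cc(OC)cc3n2S(=O)(=O)c2ccc(OC)cc2)cc1` is the point of departure; in a functional assay on SUP-B15 cells (Homo sapiens) for antiproliferative activity, with a stated time of 72 h (on this read-out higher numbers stand for an effect only at larger amounts of compound and lower numbers for an effect already at smaller amounts), compound 3 gives > 82700 nM, which is a limit of the assay and not a number. Its neighbours are compound 1 `COc1ccc(-c2cc(=O)c3c(OC)cc(OC)cc3n2S(=O)(=O)c2ccc(F)cc2)cc1` and compound 2 `COc1ccc(-c2cc(=O)c3c(OC)cc(OC)cc3n2S(=O)(=O)c2ccc(Br)cc2)cc1`. In this assay compound 1 gives > 65500 nM, again a limit of the assay. In this assay compound 2 gives 63800 nM. The step of an at least 1.0-fold lower number from compound 1 to compound 2 (0.01 log units; that floor lies within the scatter) and the step of an at least 1.2-fold higher number from compound 2 to compound 3 (0.11 log units; that floor lies within the scatter) are both floors within the scatter, and the step that the two limits leave unreadable from compound 1 to compound 3 cannot be read, as the two limits the limit of > 65500 nM in this assay, at which 1 of the 3 values shown sits, and the limit of > 82700 nM in this assay, at which 1 of the 3 values shown sits, show. None of the three measured compounds separates from the others in this assay.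

Compound 4 `COc1ccc(-c2cc(=O)c3c(OC)cc(OC)cc3n2S(=O)(=O)Cc2ccccc2)cc1` is not yet measured. The change from compound 3 is benzyl in place of 4-methoxyphenyl on a sulfonyl sulfur. Within the data shown here, no measured step concerns the group on the sulfonyl sulfur itself; the measured steps only exchange a substituent on the aryl ring of that group, and all of them leave the numbers at or near the limits. Nothing therefore points to a step beyond the scatter, and the step of an at least 1.0-fold lower number from compound 3 to compound 4 (0.01 log units; that floor lies within the scatter) is expected to stay within it. Compound 4 is expected to give about 80000 nM in this assay, within a range from 30000 nM to 200000 nM, with a fair chance that only a limit is reported.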

Compound 4, half-maximal effective concentration: > 34400 nM
Compound 4 ended at the assay's limit; the forecaster's own chance of this, stated with the estimate: 60%; the middle value is on the limit's open side.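

In this assay compound 4 gives > 34400 nM, which is a limit of the assay and not a number. Its steps from compound 1, compound 2 and compound 3 cannot be read. The compounds shown leave open whether benzyl on the sulfonyl sulfur differs at all from 4-methoxyphenyl, 4-bromophenyl or 4-fluorophenyl there.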